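The source may hold more compounds than are shown below. What is called first, only, known or untested is meant among the compounds shown, and "the series" means these compounds.

Compound 1 `COc1ccc(/C=C/c2cc(C)n[nH]2)cc1` is measured in a functional assay on MDA-MB-231 cells (Homo sapiens) for cytotoxicity, read by MTT assay, with a stated time of 72 h (on this read-out higher numbers stand for weaker inhibition and lower numbers for stronger inhibition), where compound 1 gives 10700 nM. Compound 2 `COc1ccc(/C=C/c2cc(C)n[nH]2)cc1OC` carries one change relative to compound 1, (methoxy in place of hydrogen on an aromatic carbon), and in this assay compound 2 gives 38800 nM, a step of a 3.6-fold higher number from compound 1 to compound 2 (0.56 log units; beyond the scatter). Compound 3 `Cc1cc(/C=C/c2ccc(O)cc2)on1` is built on a different core; how its core differs from that of compound 1 is not broken down here. In this assay compound 3 gives 55500 nM, a number close to that of compound 2 and within the usual scatter of it. Compound 4 `COc1cc(/C=C/c2cc(C)no2)ccc1O` has not been measured. It differs from compound 3 by methoxy in place of hydrogen on an aromatic carbon. This is the same kind of change as that from compound 1 to compound 2, though not the same: in compound 4 the entering group sits ortho to a hydroxy group, whereas in compound 2 it sits ortho to a methoxy group. Resting on the measured step of a 3.6-fold higher number from compound 1 to compound 2 (0.56 log units; beyond the scatter), compound 4 is expected in this assay to show a step of about a 1.4-fold higher number from compound 3 to compound 4 (0.16 log units; within the scatter). Compound 4 is therefore estimated at 80000 nM, between 30000 nM and 220000 nM.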

Compound 4, half-maximal inhibitory concentration: 34600 nM
The estimate for compound 4 lay 2.3-fold (0.36 log units) above the measured number; the range from low to high includes it.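

In this assay, among the compounds shown here, methoxy in place of hydrogen on an aromatic carbon gives a 1.6-fold lower number from compound 3 to compound 4 (0.21 log units; within the scatter), so on the core of compound 3 this change produces no step that stands clear of the scatter. Set beside the earlier step, the change does not carry over in size from one core to the other: the same change on two cores in this assay, a 3.6-fold higher number (0.56 log units; beyond the scatter) from compound 1 to compound 2 and a 1.6-fold lower number (0.21 log units; within the scatter) from compound 3 to compound 4, 5.8-fold (0.76 log units) apart, beyond the scatter of two such steps. This does not show that the core alone sets the outcome, since the entering methoxy in compound 4 sits ortho to a hydroxy group and compound 2 holds no hydroxy group, and two pairs cannot separate these differences.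

As far as these compounds go, it remains open how the same change would read on the core of compound 1 with a hydroxy group in that ring, or on the core of compound 3 with a methoxy group in place of the hydroxy group. Also open, from the compounds shown here alone, is whether an amine, a carboxylic acid or a longer chain such as ethoxy in the same place would follow either step.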